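A longer chain on compound 1

A few compounds are considered here, and "the series" means these few. Any claim that something is new, unique, unknown or untested is made for them only; others in the source may bear on it.

In a functional assay on SW480 cells (Homo sapiens) for antiproliferative activity, read by MTT assay, with a stated time of 48 h (on this read-out lower numbers stand for stronger inhibition and higher numbers for weaker inhibition), compound 1 (`CCCCC(CCO)n1cnc2c(Cl)ncnc21`) gives > 50000 nM, which is a limit of the assay and not a number. Compound 2 (`CCCCC(CCO)n1cnc2c(OC)ncnc21`) gives > 50000 nM, also a limit. Compound 3 (`CCCCC(CCO)n1cnc2c(N)ncnc21`) gives > 50000 nM, again a limit. All three therefore sit at the limit of > 50000 nM in this assay, at which 3 of the 3 values shown sit.

Compound 4 (`CCCCCCCC(CCO)n1cnc2c(Cl)ncnc21`) differs from compound 1 by propyl in place of hydrogen on a saturated chain carbon, five bonds along the chain from an aromatic nitrogen. The measured steps, a step that the two limits leave unreadable from compound 1 to compound 2, a step that the two limits leave unreadable from compound 1 to compound 3 and a step that the two limits leave unreadable from compound 2 to compound 3, change an aromatic substituent and leave the chain untouched, so none gives a size to carry over. Only a modest move towards stronger inhibition is expected, and it may stay unreadable. The expected step is an at least 1.4-fold lower number from compound 1 to compound 4 (0.15 log units; that floor lies within the scatter). Compound 4 is expected at 35000 nM, with an estimated range of 12000 nM to 70000 nM.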

Compound 4, half-maximal inhibitory concentration: 3630 nM
Beside the measured number, compound 4's estimate is 9.6-fold (0.98 log units) above it, outside the stated range (below it).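

In this assay, propyl in place of hydrogen on a saturated chain carbon, five bonds along the chain from an aromatic nitrogen, gives an at least 13-fold lower number from compound 1 to compound 4 (1.13 log units; beyond the scatter). This chain position therefore carries a change that can be read, while the steps among compound 1, compound 2 and compound 3, all on an aromatic carbon, cannot be read. Compound 4 alone among the compounds shown stands clear of the limit: the limit of > 50000 nM in this assay, at which 3 of the 4 values shown sit.

On these data alone, whether a shorter addition such as methyl, or a longer chain than propyl, would move the number further stays open. Also open, as far as these compounds go, is whether methoxy or amino in place of chloro would read differently on the chain of compound 4.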